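Adding One Chloro Group to Compound 1

This account rests on a few compounds, and the source may have more. Where it says the series, first, only, none or still open, it means among the compounds named here.

In a functional assay on HeLa cells (Homo sapiens) for antiproliferative activity, read by MTT assay, with a stated time of 48 h (a higher number here means a weaker inhibitor, a lower number a stronger inhibitor), compound 1 `Oc1ccc2ccccc2c1C(Nc1nc2ccccc2s1)c1cn(-c2ccccc2)nc1-c1ccccc1` gives 17300 nM. Its close relative compound 2 `Cc1cccc(-c2nn(-c3ccccc3)cc2C(Nc2nc3ccccc3s2)c2c(O)ccc3ccccc23)c1` gives 7020 nM, and compound 3 `COc1ccc(-c2nn(-c3ccccc3)cc2C(Nc2nc3ccccc3s2)c2c(O)ccc3ccccc23)cc1` gives 9340 nM. Compound 4 `Oc1ccc2ccccc2c1C(Nc1nc2ccc(Cl)cc2s1)c1cn(-c2ccccc2)nc1-c1ccccc1` keeps the core of compound 1 and alters a single place: chloro in place of hydrogen on an aromatic carbon. This change turns 1,3-benzothiazol-2-yl into 6-chloro-1,3-benzothiazol-2-yl.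

The nearest evidence comes from two other replacements of hydrogen, made elsewhere in the molecule. Methyl in compound 2 gives a 2.5-fold lower number from compound 1 to compound 2 (0.39 log units; beyond the scatter), a modest step, and methoxy in compound 3 gives a 1.9-fold lower number from compound 1 to compound 3 (0.27 log units; within the scatter). Within the data shown here, no measured compound carries a change on the ring that receives the chloro, so these steps are only a loose guide. They point to a small drop in the number, possibly none beyond the scatter. The estimated step is a 1.9-fold lower number from compound 1 to compound 4 (0.28 log units; within the scatter). For compound 4 the expected value is 9000 nM, with an estimated range from 3500 nM to 20000 nM.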

Compound 4, half-maximal inhibitory concentration: 12500 nM
Beside the measured number, compound 4's estimate is 1.4-fold (0.14 log units) below it, and the stated range covers the measured number.
By their numbers in this assay, from the lowest: compounds 2, 3, 4 and 1 (each within the scatter of the next, the first and the last beyond it).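

In this assay, chloro in place of hydrogen, which turns 1,3-benzothiazol-2-yl into 6-chloro-1,3-benzothiazol-2-yl, gives a 1.4-fold lower number from compound 1 to compound 4 (0.14 log units; within the scatter). Among these compounds, this is the first view of a change on this ring, since the earlier compounds differ only on other parts of the molecule, and here a single chlorine atom leaves the number indistinguishable from that of compound 1. No accompanying measurement offers an explanation for this outcome.

The compounds shown leave open whether a different group at this position, such as an amine or a carboxylic acid, would shift the number beyond the scatter. They also leave open whether chloro would behave the same way on another aromatic carbon of this ring, or when combined with the methyl group of compound 2.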